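Moving a Hydroxy Group Around a Phenyl Ring

The source may hold more compounds than are shown below. What is called first, only, known or untested is meant among the compounds shown, and "the series" means these compounds.

Three compounds sharing one core have been measured in a physicochemical assay for solubility, read by spectrophotometry, in phosphate buffer, with a stated time of 18 h, at pH 7.4; a lower number here means a less soluble compound, a higher number a more soluble compound:

Compound 1, `CCc1ccc(-c2nc3c(c(C)nn3-c3ccccc3)c(-c3ccccc3O)c2C#N)cc1`: 3100 nM
Compound 2, `CCc1ccc(-c2nc3c(c(C)nn3-c3ccccc3)c(-c3ccccc3I)c2C#N)cc1`: 8500 nM
Compound 3, `CCc1ccc(-c2nc3c(c(C)nn3-c3ccccc3)c(-c3ccccc3)c2C#N)cc1`: 47000 nM

Compound 1 gives the lowest number of the three. Its nearest neighbour is compound 2, with a 2.7-fold higher number from compound 1 to compound 2 (0.44 log units; beyond the scatter), and the furthest is compound 3, with a 15-fold higher number from compound 1 to compound 3 (1.18 log units; beyond the scatter). Between the other two, a 5.5-fold higher number from compound 2 to compound 3 (0.74 log units; beyond the scatter).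

Compound 4, `CCc1ccc(-c2nc3c(c(C)nn3-c3ccccc3)c(-c3cccc(O)c3)c2C#N)cc1`, has not yet been measured. It differs from compound 1 in one place: 3-hydroxyphenyl in place of 2-hydroxyphenyl on an aromatic carbon. The two have the same atoms, joined differently.

Within the data shown here, no measured step moves the hydroxy from one position to another. The two steps that touch it take it away, either by replacing it with iodo or with hydrogen, and both raise the number, one modestly and one by a large amount. Keeping the hydroxy but shifting it is a smaller alteration than removing it, so only a modest rise, or a step within the usual scatter, is expected. Compound 4 is therefore estimated at 5500 nM, with a range from 2000 nM to 15000 nM. The expected step is a 1.8-fold higher number from compound 1 to compound 4 (0.25 log units; within the scatter).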

Compound 4, solubility: 18000 nM
For compound 4 the middle estimate is 3.3-fold (0.51 log units) below the measured one, and the stated range ends below it.
By their numbers in this assay, from the lowest: compound 1; then compound 2; then compound 4; then compound 3.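

Moving the hydroxy around the ring, with no atom gained or lost, is enough on its own to change the number in this assay: the shift to 3-hydroxyphenyl gives a 5.8-fold higher number from compound 1 to compound 4 (0.76 log units; beyond the scatter) while the counted donors and acceptors stay the same. A hydroxy on the ring therefore does not bring one fixed drop, since adding it as in compound 4 gives a 2.6-fold lower number from compound 3 to compound 4 (0.42 log units; beyond the scatter) whereas the 2-hydroxyphenyl group of compound 1 sits lower, as the step of a 15-fold higher number from compound 1 to compound 3 (1.18 log units; beyond the scatter) shows when read from the other side. The earlier order, with the hydroxy compound under the iodo compound, also holds only for 2-hydroxyphenyl. The step of a 2.1-fold higher number from compound 2 to compound 4 (0.33 log units; beyond the scatter) puts 3-hydroxyphenyl above 2-iodophenyl.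

Nothing shown here explains why the shift has this effect. Still open, going by these compounds, is where 4-hydroxyphenyl on the same carbon would fall, and whether a methoxy or an amine in place of the hydroxy would follow the same dependence on ring position.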